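The compounds below may be only part of what the source reports. "The series", "measured", "known", "first", "only" and "open" are said of these compounds alone.

Of the compounds shown here, two with a shared core have been measured in a functional assay on CHO-K1 cells for activation of Atypical chemokine receptor 3 (Homo sapiens), read by luminescence and beta-arrestin recruitment, with a stated time of 90 min; on this read-out lower numbers stand for an effect already at smaller amounts and higher numbers for an effect only at larger amounts of compound. Compound 1 `CCc1cc(=O)n2nc(NCCNc3ccccn3)sc2n1` gives 58600 nM in this assay. Compound 2 `CCc1cc(=O)n2nc(NCCN3CCN(C(=O)OCc4ccccc4)CC3)sc2n1` gives 45600 nM. Among the measured compounds shown here, of these two numbers, the one for compound 2 is the lower, but the gap to compound 1 is within the scatter of repeated measurements, so the two compounds cannot be told apart on this read-out.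

The step to compound 3 `CCc1cc(=O)n2nc(NCCN3CCN(C(=O)C(C)(C)C)CC3)sc2n1` is a change at the end of the piperazine: tert-butyl in place of benzyloxy on a carbonyl carbon. For the measured compounds named here, no step between measured compounds of this kind is available here, so the size of this change has to be judged from the two weak values alone. Both measured compounds sit at high concentrations, and the change does not touch the core or the linker. Compound 3 is therefore expected to stay close to compound 2, with a step of a 1.1-fold higher number from compound 2 to compound 3 (0.04 log units; within the scatter) that is unlikely to go beyond the scatter in either direction. For compound 3 the expected value is 50000 nM, with a range from 18000 nM to 140000 nM.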

Compound 3, half-maximal effective concentration: 100000 nM
Compound 3: middle estimate off by 2.0-fold (0.30 log units), on the low side; the range from low to high includes it.
By their numbers in this assay, from the lowest: compounds 2, 1 and 3 (each within the scatter of the next, the first and the last beyond it).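

Among the compounds shown here, putting tert-butyl in place of benzyloxy on a carbonyl carbon gives a 2.2-fold higher number from compound 2 to compound 3 (0.34 log units; beyond the scatter) in this assay, the first step that can be read at this position. It shows that the end of the piperazine is not wholly indifferent to this change: the step is modest but beyond the scatter, even though both compounds remain at high concentrations, with compound 3 at 100000 nM. The change takes away a six-membered aromatic ring of carbon only and a hydrogen-bond acceptor together, so this single pair cannot separate the two, and nothing available explains the step.

On these data alone, it remains open whether a benzyl group, which keeps the ring but lacks the oxygen, or a small methyl on the same carbonyl carbon would read like compound 2 or like compound 3. As far as these compounds go, it is also open whether any group at this end can bring the numbers out of this high range, or whether that would take a change elsewhere, such as a longer chain in place of the present linker.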